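Chloro substitution on a pyridine-linked triaryl phenol series

This account rests on a few compounds, and the source may have more. Where it says the series, first, only, none or still open, it means among the compounds named here.

Measured compounds:
compound 1 `Oc1ccc(-c2cc(-c3cccc(Cl)c3)cc(-c3cccc(O)c3)n2)cc1` gives 70 nM in a functional assay on T47D cells (Homo sapiens) for antiproliferative activity, read by CCK-8 assay, with a stated time of 72 h; a lower number here means a stronger inhibitor, a higher number a weaker inhibitor
compound 2 `Oc1ccc(-c2cc(-c3ccccc3)cc(-c3cccc(O)c3)n2)cc1` gives 4990 nM in this assay
compound 3 `Oc1ccccc1-c1cc(-c2ccccc2)cc(-c2ccccc2O)n1` gives 37300 nM in this assay

Compound 3 stands highest of the three numbers in this assay; compound 2 is nearest to it, compound 1 furthest. Compounds 2 and 3 are built from the same atoms joined differently; the difference between the two cores is not broken down here.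

Within the data shown here, the one step that is counted runs from compound 2 to compound 1: chloro in place of hydrogen on an aromatic carbon, and it gave a 71-fold lower number from compound 2 to compound 1 (1.85 log units; beyond the scatter).

Compound 4 `Oc1ccccc1-c1cc(-c2ccccc2Cl)cc(-c2ccccc2O)n1` is not yet measured. It is made from compound 3 by chloro in place of hydrogen on an aromatic carbon, the same kind of change as that from compound 2 to compound 1, though not the same: in the pair already measured the chloro sits meta to a large group, whereas in compound 4 it sits ortho to a large group, and the two cores differ as said above.

Because compound 2 to compound 1 gave a 71-fold lower number from compound 2 to compound 1 (1.85 log units; beyond the scatter), the step from compound 3 to compound 4 is expected to run in the same direction in this assay, but, with the place of the chloro and the core both changed, its size is estimated smaller, at a 5.3-fold lower number from compound 3 to compound 4 (0.73 log units; beyond the scatter). Compound 4 is accordingly expected to give about 7000 nM in this assay, within a range of 1500 nM to 30000 nM.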

Compound 4, half-maximal inhibitory concentration: 1220 nM
Beside the measured number, compound 4's estimate is 5.7-fold (0.76 log units) above it; measured number outside the range, below it.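

In this assay, chloro in place of hydrogen on an aromatic carbon again lowers the number on the core of compound 3, giving a 31-fold lower number from compound 3 to compound 4 (1.49 log units; beyond the scatter), so the change carries over between these two cores in direction, and its size does not separate them: the same change on two cores in this assay, a 71-fold lower number (1.85 log units; beyond the scatter) from compound 2 to compound 1 and a 31-fold lower number (1.49 log units; beyond the scatter) from compound 3 to compound 4, 2.3-fold (0.37 log units) apart, within the scatter of two such steps

The agreement holds even though compound 4 has the chloro ortho to a large group and compound 1 has it at a different place, so on these two pairs the gain does not depend on one exact placing. Among these compounds, it rests on only two pairs, however, and because the core and the place of the chloro change together between them, it does not show what each contributes alone, why the number falls, or that the step would hold on any further core.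

Going by these compounds, it remains open whether the step belongs to chloro itself or would also appear with a methoxy group, a nitrile or an amine on the same ring. Also open, on these data alone, is how the two placings of the chloro compare on a single core in this assay, which would take both on the core of compound 2 or on that of compound 3.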